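A few compounds are considered here, and "the series" means these few. Any claim that something is new, unique, unknown or untested is made for them only; others in the source may bear on it.

Compound 1 `O=C(Nc1ccc(-n2ncc3c(Cl)cccc32)cc1)Nc1ccc(Cl)c(C(F)(F)F)c1` gives 3100 nM in a functional assay on A549 cells (Homo sapiens) for cytotoxicity, read by MTT assay, with a stated time of 72 h; a higher number here means a weaker inhibitor, a lower number a stronger inhibitor. Compound 2 `O=C(Nc1ccc(-n2ncc3c(Br)cccc32)cc1)Nc1ccc(Cl)c(C(F)(F)F)c1` gives 2300 nM in this assay, and compound 3 `O=C(Nc1ccc(-n2ncc3c(F)cccc32)cc1)Nc1ccc(Cl)c(C(F)(F)F)c1` gives 3800 nM. Compound 3 thus sits at the upper end of the three numbers, but the step of a 1.2-fold higher number from compound 1 to compound 3 (0.09 log units; within the scatter) and the step of a 1.7-fold higher number from compound 2 to compound 3 (0.22 log units; within the scatter) both lie within the scatter, as does the step of a 1.3-fold lower number from compound 1 to compound 2 (0.13 log units; within the scatter), so the three compounds cannot be told apart on these numbers.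

Compound 4 `COc1cccc2c1cnn2-c1ccc(NC(=O)Nc2ccc(Cl)c(C(F)(F)F)c2)cc1` has not yet been measured. It differs from compound 3 in one place: methoxy in place of fluoro on an aromatic carbon. The three measured steps each exchange one halogen for another on this same aromatic carbon, and none of them moved this assay beyond the scatter. Among the measured compounds shown here, no measured step exchanges a halogen for a methoxy, so the closest guidance is that this position has so far tolerated changes without a shift beyond the scatter. The estimated step is therefore a 1.1-fold lower number from compound 3 to compound 4 (0.04 log units; within the scatter), small in either direction. Compound 4 is expected to give 3500 nM in this assay, with a range from 1200 nM to 10000 nM to allow for an untested kind of change.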

Compound 4, half-maximal inhibitory concentration: 3700 nM
The estimate for compound 4 lay 1.1-fold (0.02 log units) below the measured number; the measured number falls inside the stated range.
By their numbers in this assay, from the lowest: compounds 2, 1, 4 and 3 (each within the scatter of the next).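

Among the compounds shown here, the methoxy group of compound 4 is the first group on this aromatic carbon that is not a halogen, and it brings two heavy atoms and a hydrogen-bond acceptor where the halogens brought one heavy atom and no acceptor. In this assay the steps of a 1.0-fold lower number from compound 3 to compound 4 (0.01 log units; within the scatter) and a 1.2-fold higher number from compound 1 to compound 4 (0.08 log units; within the scatter) and also a 1.6-fold higher number from compound 2 to compound 4 (0.21 log units; within the scatter) all stay within the scatter, which places compound 4 among the halogen compounds and extends the tolerance seen for fluoro, chloro and bromo at this carbon to a group attached through oxygen. Nothing available here accounts for this tolerance.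

The compounds shown leave open whether an amine, a carboxylic acid or a longer chain such as butoxy on this same carbon would also stay within the scatter, or whether one of them would give the first step beyond it. They also leave open how much the rest of the shared core contributes to the numbers, as every compound here keeps it unchanged.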